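Removing One Methoxy Group From a Trimethoxyphenyl Arm

This account rests on a few compounds, and the source may have more. Where it says the series, first, only, none or still open, it means among the compounds named here.

Of the compounds shown here, three sharing a common core have been measured in a functional assay on QGY-7703 cells (Homo sapiens) for cytotoxicity, read by MTT assay, with a stated time of 24 h; a lower number here means a stronger inhibitor, a higher number a weaker inhibitor. Compound 2 `COc1cc(/C=C2\CN(S(=O)(=O)c3ccc(F)cc3)C/C(=C\c3cc(OC)c(OC)c(OC)c3)C2=O)cc(OC)c1` gives 5200 nM. Compound 1 `COc1cc(/C=C2\CN(S(=O)(=O)c3ccc(F)cc3)C/C(=C\c3cc(OC)cc(OC)c3)C2=O)cc(OC)c1` differs from it by one change, (hydrogen in place of methoxy on an aromatic carbon), and gives 11400 nM; this step, a 2.2-fold higher number from compound 2 to compound 1 (0.34 log units; beyond the scatter), shows that losing the methoxy group weakens the compound by a modest amount that is beyond the usual scatter.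

Compound 3 `COc1cc(/C=C2\CN(S(=O)(=O)c3ccc(NC(C)=O)cc3)C/C(=C\c3ccccc3F)C2=O)cc(OC)c1OC` carries a different group on the sulfonyl arm and a different aryl arm; the difference between the cores of compound 3 and compound 2 is not broken down here. In this assay compound 3 gives 2680 nM, which is within the scatter of compound 2 and beyond the scatter of compound 1.

Compound 4 `COc1cc(/C=C2\CN(S(=O)(=O)c3ccc(NC(C)=O)cc3)C/C(=C\c3ccccc3F)C2=O)cc(OC)c1` has not been measured. It differs from compound 3 by hydrogen in place of methoxy on an aromatic carbon, the same change that turns compound 2 into compound 1. For compound 4 the step of a 2.2-fold higher number from compound 3 to compound 4 (0.34 log units; beyond the scatter) is expected, resting on the earlier step of a 2.2-fold higher number from compound 2 to compound 1 (0.34 log units; beyond the scatter) seen on the core of compound 2, applied to the value of compound 3 2680 nM. For the measured compounds named here, compound 4 is therefore expected to give about 5800 nM in this assay, with a likely range from 2700 nM to 12500 nM, since only one prior example of this change exists and the two cores differ.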

Compound 4, half-maximal inhibitory concentration: 3690 nM
Compound 4: the middle estimate sits 1.6-fold (0.20 log units) above what was measured; measured number inside the range.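

Removing the methoxy group from compound 3, which turns its 3,4,5-trimethoxyphenyl arm into a 3,5-dimethoxyphenyl arm, gives in this assay a 1.4-fold higher number from compound 3 to compound 4 (0.14 log units; within the scatter), so on this core the change cannot be told apart from the ordinary spread of repeated measurements. Set beside the earlier example, the result gives no sign that the two cores respond differently to this change: the same change on two cores in this assay, a 2.2-fold higher number (0.34 log units; beyond the scatter) from compound 2 to compound 1 and a 1.4-fold higher number (0.14 log units; within the scatter) from compound 3 to compound 4, 1.6-fold (0.20 log units) apart, within the scatter of two such steps. For the compounds shown here, this does not show that the change has one fixed size across the series, since there are only two examples, one step lies beyond the scatter and the other within it, and the two cores differ in both the group on the sulfonyl arm and the other aryl arm, so any influence of either part on the step cannot be separated.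

The compounds shown leave open what happens when something other than hydrogen takes the place of this methoxy group, such as a hydroxyl group, a fluorine atom or an amine. They also leave open whether the step stays this small on a core carrying another group on the sulfonyl arm, such as a carboxylic acid.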